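Chain amine change on the shared core in cell growth assay

The source may report more compounds than this note shows. Statements on the series, on what has been measured and on what is new or still open speak of the compounds shown alone.

Measured so far in a functional assay on NCI-H460 cells (Homo sapiens) for inhibition, read by MTT assay, with a stated time of 72 h; a higher number here means a weaker inhibitor, a lower number a stronger inhibitor:
compound 1 `Cc1ccc2c(c1)/C(=c1/sc(=Cc3ccc(C=O)c(C=O)c3)c(=O)n1CCN(C)C)C(=O)N2` gives 4030 nM
compound 2 `CCN(CC)CCCn1c(=O)c(=Cc2cc(OC)c(OC)c(OC)c2)s/c1=C1\C(=O)Nc2ccc(C)cc21` gives 2670 nM
compound 3 `CN(C)CCn1c(=O)c(=Cc2ccc(F)c(F)c2)s/c1=C1\C(=O)Nc2cc(F)ccc21` gives 6400 nM

Compound 3 has the highest of the three numbers in this assay. Its nearest neighbour is compound 1, whose number is lower but within the scatter of repeated measurements, so the two cannot be ordered. Compound 2 stands furthest from it, with a number lower by more than the scatter; compound 2 differs from compound 3 in several places at once, so no single change can be read off that pair.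

Compound 4 `CCN(CC)CCCn1c(=O)c(=Cc2ccc(F)c(F)c2)s/c1=C1\C(=O)Nc2cc(F)ccc21` is not yet measured. It differs from compound 3 in one place: (diethylamino)methyl in place of dimethylamino on a saturated chain carbon, two bonds along the chain from an aromatic nitrogen. Within the data shown here, no measured pair in this set isolates that change, so the step from compound 3 to compound 4 is unknown. The expectation is a step of no more than the usual scatter, with at most a slight lean towards a lower number: a 1.2-fold lower number from compound 3 to compound 4 (0.07 log units; within the scatter). On that basis compound 4 is estimated at 5500 nM in this assay, within a range from 2500 nM to 12000 nM.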

Compound 4, half-maximal inhibitory concentration: 1120 nM
Compound 4: middle estimate off by 4.9-fold (0.69 log units), on the high side; the measured number lies below the stated range.
By their numbers in this assay, from the lowest: compound 4; then compounds 2, 1 and 3 (each within the scatter of the next, the first and the last beyond it).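

Working notes on the chain amine: in this assay, 3-(diethylamino)propyl in place of 2-(dimethylamino)ethyl gives a 5.7-fold lower number from compound 3 to compound 4 (0.76 log units; beyond the scatter) with the rest of the structure unchanged. Among these compounds, this is the first single-place comparison, and it shows that the chain amine position can move the number beyond the scatter, though only this one pair supports that reading. No available evidence bears on why this step occurs.

The step changes chain length and the amine substituents together, so the compounds shown do not separate these contributions; a 3-(dimethylamino)propyl or 2-(diethylamino)ethyl chain would divide the step between them. Also open, from the compounds shown here alone, is whether a cyclic amine such as pyrrolidine or morpholine at the chain end would give a similar step, and whether the step carries over to other substituent patterns on the shared core.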